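The compounds below may be only part of what the source reports. "The series", "measured", "known", "first", "only" and "open" are said of these compounds alone.

Working notes on the series in a functional assay on SGC-7901 cells (Homo sapiens) for antiproliferative activity, read by MTT assay, with a stated time of 72 h; on this read-out lower numbers stand for stronger inhibition and higher numbers for weaker inhibition. Compound 1 `COc1cc2c(Nc3ccc(Cl)cc3F)ncnc2c(OC)c1OC` is placed only by a limit in this assay: compound 1 gives > 30000 nM. Two of the three values shown in this assay sit at that limit (the limit of > 30000 nM in this assay, at which 2 of the 3 values shown sit), so compound 1 stands among the weakest measured, without a number of its own. Compound 3 `COc1cc2c(Nc3ccc(C(F)(F)F)cc3)ncnc2c(OC)c1OC` likewise gives only a limit in this assay, > 30000 nM. For the measured compounds named here, compound 2 `COc1cc2c(Nc3ccc(Br)c(Cl)c3F)ncnc2c(OC)c1OC`, which carries a different group on the nitrogen of the shared core, is the one member with a number in this assay, giving 15000 nM. Going by the values given here, no step between measured compounds that differ in one place is available, so the comparison rests on these three values alone.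

Compound 4 `COc1cc2c(Nc3cc(F)ccc3Br)ncnc2c(OC)c1OC` differs from compound 1 by 2-bromo-5-fluorophenyl in place of 4-chloro-2-fluorophenyl on a nitrogen on an aromatic ring. The expected step from compound 1 to compound 4 in this assay is an at least 1.5-fold lower number from compound 1 to compound 4 (0.17 log units; that floor lies within the scatter), no larger than the scatter and uncertain in direction. Among the compounds with values here, this expectation rests on compound 2, whose value in this assay is 15000 nM, the only number. In this assay compound 4 is estimated at 20000 nM, expected to lie between 5000 nM and 60000 nM, with a considerable chance that only a limit is returned.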

Compound 4, half-maximal inhibitory concentration: 18400 nM
Compound 4: middle estimate off by 1.1-fold (0.04 log units), on the high side; low and high end bracket the measured number.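

At the place on a nitrogen on an aromatic ring, 2-bromo-5-fluorophenyl in place of 4-chloro-2-fluorophenyl gives a number in this assay where compound 1 gave only a limit, and the change reads as an at least 1.6-fold lower number from compound 1 to compound 4 (0.21 log units; that floor lies within the scatter). That step starts from a limit, so only its floor is known, and the swap of chlorine for bromine comes with a changed halogen pattern on the ring, so the two cannot be told apart here. The series as shown still leans heavily on the limit: the limit of > 30000 nM in this assay, at which 2 of the 4 values shown sit.

Going by these compounds, whether an amine or a carboxylic acid on this phenyl ring, in place of the halogens, would move the number beyond the scatter stays open. Also open, on these data alone, is what a longer chain in place of the methoxy groups on the shared core would do.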